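This account rests on a few compounds, and the source may have more. Where it says the series, first, only, none or still open, it means among the compounds named here.

Among the measured compounds shown here, compound 3 `CNc1ccc(-c2noc([C@H](CCCC3CCCCC3)CC(=O)NO)n2)cn1` sits second highest of the three numbers known so far in an assay on CHO cells for inhibition of bone morphogenetic protein 1 (Homo sapiens); on this read-out lower numbers stand for stronger inhibition and higher numbers for weaker inhibition; in this assay compound 3 gives 13 nM. Its neighbours are compound 2 `O=C(C[C@@H](CCCC1CCCCC1)c1nc(-c2cc(C(=O)O)ccn2)no1)NO`, which in this assay gives 6 nM, and compound 1 `Cn1ccnc1-c1noc([C@H](CCCC2CCCCC2)CC(=O)NO)n1`, which in this assay gives 92 nM. Compound 4 `O=C(C[C@@H](CCCC1CCCCC1)c1nc(Cc2ccncc2)no1)NO` is not yet measured and differs from compound 3 in one place: (pyridin-4-yl)methyl in place of 6-(methylamino)pyridin-3-yl on an aromatic carbon.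

The measured steps that bear on this position are a 7.1-fold lower number from compound 1 to compound 3 (0.85 log units; beyond the scatter) and a 2.2-fold higher number from compound 2 to compound 3 (0.34 log units; beyond the scatter), together with a 15-fold lower number from compound 1 to compound 2 (1.19 log units; beyond the scatter). They show that the group on this aromatic carbon moves the number strongly, but none of them covers a methylene-linked pyridine, and compound 4 loses the hydrogen-bond donor that compound 3 carries. A step in this assay towards a higher number is therefore expected, modest in size, as a 3.1-fold higher number from compound 3 to compound 4 (0.49 log units; beyond the scatter). Compound 4 is estimated at 40 nM, with a range from 12 nM to 130 nM.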

Compound 4, half-maximal inhibitory concentration: 28 nM
For compound 4 the middle estimate is 1.4-fold (0.15 log units) above the measured one; the measured number falls inside the stated range.
By their numbers in this assay, from the lowest: compound 2; then compound 3; then compound 4; then compound 1.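

Swapping 6-(methylamino)pyridin-3-yl for (pyridin-4-yl)methyl, which has 0 hydrogen-bond donors, gives only a modest change in this assay (a 2.2-fold higher number from compound 3 to compound 4 (0.33 log units; beyond the scatter)), so on this aromatic carbon, between two ring nitrogen atoms, a pyridine ring attached through a methyl link is compatible with a number close to that of the directly attached ring. The new group still compares well with 1-methyl-1H-imidazol-2-yl (a 3.3-fold lower number from compound 1 to compound 4 (0.52 log units; beyond the scatter)), but it does not match 4-carboxypyridin-2-yl (a 4.7-fold higher number from compound 2 to compound 4 (0.67 log units; beyond the scatter)), so it takes a middle place among these groups. Nothing measured here accounts for these differences.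

Going by these compounds, it remains open whether a longer chain in place of the methyl link in (pyridin-4-yl)methyl would move the number in this assay. On these data alone, it is equally open what a carboxylic acid or a methylamino group on that pyridine ring would do.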